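Ester chain branching in the malonamide series

The source may hold more compounds than are shown below. What is called first, only, known or untested is meant among the compounds shown, and "the series" means these compounds.

Compound 1 `CC(C)c1cccc(C(C)C)c1NC(=O)CC(=O)O` is the free acid; in an assay on microsomes from intestine for inhibition of acyl-CoA:cholesterol acyltransferase (Oryctolagus cuniculus) (on this read-out higher numbers stand for weaker inhibition and lower numbers for stronger inhibition), compound 1 gives > 5000 nM and that is a reading at the limit of > 5000 nM in this assay, at which 1 of the 3 values shown sits, rather than a number. Compound 2 `CCOC(=O)CC(=O)Nc1c(C(C)C)cccc1C(C)C` gives 1800 nM in this assay and compound 3 `CCCCCC(C)OC(=O)CC(=O)Nc1c(C(C)C)cccc1C(C)C` gives 27 nM there. The measured steps are an at least 2.7-fold lower number from compound 1 to compound 2 (0.44 log units; beyond the scatter) and an at least 180-fold lower number from compound 1 to compound 3 (2.26 log units; beyond the scatter) and a 67-fold lower number from compound 2 to compound 3 (1.82 log units; beyond the scatter) so compound 3 holds the lowest number of the two shown and compound 2 sits beyond the scatter above it while compound 1 contributes only a limit.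

Compound 4 `CCCCC(C)(C)OC(=O)CC(=O)Nc1c(C(C)C)cccc1C(C)C` differs from compound 3 in one place: 1,1-dimethylpentyl in place of 1-methylhexyl on an oxygen next to a carbonyl group so the ester substituent keeps its size. Going by the values given here, no measured step rearranges an ester chain in this way; the nearest comparisons are a 67-fold lower number from compound 2 to compound 3 (1.82 log units; beyond the scatter) and an at least 2.7-fold lower number from compound 1 to compound 2 (0.44 log units; beyond the scatter) which both changed the amount of carbon on the ester oxygen rather than its arrangement. The step in this assay is therefore expected to stay within the scatter as a 1.3-fold higher number from compound 3 to compound 4 (0.11 log units; within the scatter) and compound 4 is expected to give about 35 nM in this assay with a range from 10 nM to 120 nM until the measurement is in hand.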

Compound 4, half-maximal inhibitory concentration: 15 nM
Beside the measured number, compound 4's estimate is 2.3-fold (0.37 log units) above it; measured number inside the range.
By their numbers in this assay, from the lowest: compounds 4 and 3 (each within the scatter of the next); then compound 2. At a limit, above all of these: compound 1.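

In this assay, the position on an oxygen next to a carbonyl group accepts a rearranged chain: 1,1-dimethylpentyl in place of 1-methylhexyl keeps the same atoms, joined differently, and gives a 1.8-fold lower number from compound 3 to compound 4 (0.26 log units; within the scatter), so the two chains cannot be told apart here. The earlier steps shown here changed only the amount of carbon at this position, and the new chain also stands well clear of the ethyl ester, with a 120-fold lower number from compound 2 to compound 4 (2.08 log units; beyond the scatter). The step from the free acid, an at least 330-fold lower number from compound 1 to compound 4 (2.52 log units; beyond the scatter), rests on a limit and not on a number: the limit of > 5000 nM in this assay, at which 1 of the 4 values shown sits.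

Going by these compounds, whether a cyclohexyl group, a longer chain or a chain carrying an amine would keep numbers this low at this position remains open. On these data alone, the shared core stays the same throughout, so what its parts contribute also remains open.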